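The source may report more compounds than this note shows. Statements on the series, on what has been measured and on what is new or still open speak of the compounds shown alone.

Compound 2 `CCC1(Cc2ccccc2)OS(=O)(=O)C=C1OC` carries a methyl on the oxygen of the shared core. In an ADME assay on HEL cells (Homo sapiens) for cytotoxicity, with a stated time of 3 days (a higher number here means that more compound is tolerated, a lower number that less compound is tolerated), compound 2 reaches only a limit of the assay, > 400000 nM, so its place on the scale is known as a bound rather than as a number. Compound 1 `CCC1(Cc2ccccc2)OS(=O)(=O)C=C1OCc1ccc(F)cc1` is the related compound with a 4-fluorobenzyl group in that position. In this assay compound 1 also stops at a limit of the assay, >= 50000 nM. The step that the two limits leave unreadable from compound 1 to compound 2 cannot be sized because both of its ends sit on limits: the limit of > 400000 nM in this assay, at which 1 of the 2 values shown sits, and (the limit of >= 50000 nM in this assay, at which 1 of the 2 values shown sits). Compound 3 `CCC1(Cc2ccccc2)OS(=O)(=O)C=C1OCc1ccccc1Cl` differs from compound 2 by 2-chlorophenyl in place of hydrogen on a saturated chain carbon bound to an oxygen on an unsaturated carbon. Going by the values given here, the only measured step bearing on this change is that unreadable one between compound 1 and compound 2, so no readable step points to a direction, and no shift beyond the scatter can be claimed. Compound 1, which carries a related benzyl group, gives >= 50000 nM, and compound 3 is therefore expected to come out near that limit. Compound 3 is estimated at 100000 nM, within 30000 nM to 400000 nM, an expected step of an at least 4.0-fold lower number from compound 2 to compound 3 (0.60 log units; beyond the scatter).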

Compound 3, minimum cytotoxic concentration: >= 20000 nM
Compound 3 ended at the assay's limit; the forecaster's own chance of this, stated with the estimate: 70%; the middle value is on the limit's open side.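

Compound 3 also stops at a limit of this assay, so neither its step from compound 2 nor its step from compound 1 can be read: the limit of >= 20000 nM in this assay, at which 1 of the 3 values shown sits.

The compounds shown leave open where any of the three truly lies on the scale, and so whether methyl, 4-fluorobenzyl and 2-chlorobenzyl on the oxygen differ at all in this assay.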